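Pentyloxy to isopentyloxy on the shared core

The source may report more compounds than this note shows. Statements on the series, on what has been measured and on what is new or still open speak of the compounds shown alone.

Among the measured compounds shown here, in a functional assay on brain (Rattus norvegicus, strain Wistar) for inhibition (a lower number here means a stronger inhibitor, a higher number a weaker inhibitor), compound 1 `CCCCCc1ccc(-c2c(C)[nH]c(=O)n2C2CCCCC2)cc1` gives 10600 nM and compound 2 `CCCCCOc1ccc(-c2c(C)[nH]c(=O)n2C2CCCCC2)cc1` gives 9100 nM, so compound 2 stands within the scatter of the only other measured number. Compound 3 `Cc1[nH]c(=O)n(C2CCCCC2)c1-c1ccc(OCCC(C)C)cc1` carries isopropyl in place of propyl on a saturated chain carbon, two bonds along the chain from an oxygen on an aromatic ring. For the measured compounds named here, no measured step tests this change directly. Only a 1.2-fold lower number from compound 1 to compound 2 (0.07 log units; within the scatter), pentyloxy in place of pentyl on an aromatic carbon, bears on it indirectly. The expected step in this assay is a 1.0-fold lower number from compound 2 to compound 3 (0.00 log units; within the scatter), none beyond the scatter. Compound 3 is expected at 9000 nM, with an estimated range of 4500 nM to 18000 nM.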

Compound 3, half-maximal inhibitory concentration: 7200 nM
Compound 3: middle estimate off by 1.3-fold (0.10 log units), on the high side, within the range that was stated.
By their numbers in this assay, from the lowest: compounds 3, 2 and 1 (each within the scatter of the next).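

In this assay, isopropyl in place of propyl on this saturated chain carbon gives a 1.3-fold lower number from compound 2 to compound 3 (0.10 log units; within the scatter), so the branched and straight chains are not told apart at this position. Isopentyloxy in place of pentyl gives a 1.5-fold lower number from compound 1 to compound 3 (0.17 log units; within the scatter), so even the two changes taken together leave compound 3 and compound 1 within the scatter of each other. No supporting data bear on this result. Open, from the compounds shown here alone, is whether an amine or a carboxylic acid at the chain end, or a longer chain, would give a step beyond the scatter.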